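The source may report more compounds than this note shows. Statements on the series, on what has been measured and on what is new or still open speak of the compounds shown alone.

Compound 3, `C=CCn1c(=O)/c(=C\c2ccc(F)c(Br)c2)[nH]c(=O)/c1=C\c1ccccc1OC`, is the starting point of this step and in a functional assay on K562 cells (Homo sapiens) for cytotoxicity, read by CCK-8 assay, with a stated time of 72 h (a lower number here means a stronger inhibitor, a higher number a weaker inhibitor), is recorded as "not active" (no number reported). In this assay compound 3 thus showed no measurable inhibition, and no number was reported for it, so it stands apart from the two compounds that did give values. Those are compound 1, `COc1ccccc1/C=c1\c(=O)[nH]/c(=C/c2cccc(Cl)c2Cl)c(=O)n1C`, which in this assay gives 110 nM, and compound 2, `COc1ccccc1/C=c1\c(=O)[nH]/c(=C/c2ccccc2Cl)c(=O)n1C`, which in this assay gives 110 nM; the step of no change at the digits printed from compound 1 to compound 2 (within the scatter) came with hydrogen in place of chloro on an aromatic carbon. Compound 4, `C=CCn1c(=O)/c(=C\c2ccccc2C(F)(F)F)[nH]c(=O)/c1=C\c1ccccc1OC`, differs from compound 3 by 2-(trifluoromethyl)phenyl in place of 3-bromo-4-fluorophenyl on a double-bonded chain carbon bound to an aromatic carbon. Among the compounds with values here, no measured step covers this exchange, and the one measured step, no change at the digits printed from compound 1 to compound 2 (within the scatter), concerns a different position on a different core substitution, so it does not fix the size of what follows. Compound 3 offers no number from which a step could be reckoned, and the direction can only be guessed from compounds 1 and 2 recovering activity. For compound 4 an inhibitory concentration of 600 nM is therefore expected, within a range of 100 nM to 5000 nM.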

Compound 4, half-maximal inhibitory concentration: 2700 nM
Estimate against measurement, compound 4: 4.5-fold (0.65 log units) below, within the range that was stated.
By their numbers in this assay, from the lowest: compounds 1 and 2 (each within the scatter of the next); then compound 4.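

Within the data shown here, compound 3 has no number in this assay, so no step from it to compound 4 can be read. Nothing shown accounts for this result. The compounds shown leave open how 2-(trifluoromethyl)phenyl and 3-bromo-4-fluorophenyl compare where both give numbers.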